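The source may hold more compounds than are shown below. What is called first, only, known or untested is meant among the compounds shown, and "the series" means these compounds.

Results so far in an ADME assay (MDM cells, Homo sapiens) for cytotoxicity, read by resazurin assay, with a stated time of 3 days (on this read-out lower numbers stand for stronger inhibition and higher numbers for weaker inhibition), cover three compounds:

- Compound 1 `CCCSc1nnc(COc2ccccc2C2=NOC(c3ccc(Cl)cc3Cl)C2)n1NC(=O)c1ccccc1` gives 14.8 ug/mL
- Compound 2 `C=CCSc1nnc(COc2ccccc2C2=NOC(c3ccc(Cl)cc3Cl)C2)n1NC(=O)CCl` gives "not determined" (no result reported)
- Compound 3 `CCOC(=O)CC(=O)CSc1nnc(COc2ccccc2C2=NOC(c3ccc(Cl)cc3Cl)C2)n1NC(=O)CCl` gives "not determined" (no result reported)

Compound 3 has no place on the numerical scale, since its entry "not determined" (no result reported) holds no result. Among the measured compounds shown here, the same is true of compound 2, which leaves compound 1 with the only number in the set.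

The next compound is compound 4 `CCCSc1nnc(COc2ccccc2C2=NOC(c3ccc(Cl)cc3Cl)C2)n1NC(=O)CCl`, which keeps most of the structure of compound 3. The structural change is ethyl in place of ((ethoxycarbonyl)methyl)carbonyl on a saturated chain carbon bound to a sulfur.

For the measured compounds named here, with no number for compound 3, this change has no measured starting point, and no measured step between compounds is available as a guide in this assay either. Going by the values given here, the only anchor is compound 1 at 14.8 ug/mL, so the expectation is for compound 4 to differ from that value by no more than the usual scatter, in neither direction in particular. One reference compound is thin support, so the range is kept wide. For compound 4 the estimated value is 13 ug/mL, with an expected range from 4 ug/mL to 40 ug/mL.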

Compound 4, half-maximal inhibitory concentration: 28.7 ug/mL
Estimate against measurement, compound 4: 2.2-fold (0.34 log units) below, within the range that was stated.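

Chloromethyl in place of phenyl on a carbonyl carbon, with the propylsulfanyl group and the rest of the core kept, gives a 1.9-fold higher number from compound 1 to compound 4 (0.29 log units; within the scatter) in this assay and so provides the first measured step in this set. Among the compounds shown here, this step shows that these two quite different groups on the carbonyl carbon cannot be told apart on this read-out, which the single value of compound 1 could not show. The other comparisons with compound 4 cannot be read, including the exchange of ((ethoxycarbonyl)methyl)carbonyl for ethyl on a saturated chain carbon bound to a sulfur, since neither compound 2 nor compound 3 has a result, and no other measurement bears on this result.

The compounds shown leave open whether any group on the carbonyl carbon, such as an aminomethyl group or a longer chain, would give a step beyond the usual scatter. They also leave open how much the group on the saturated chain carbon bound to a sulfur matters, as a carboxylic acid or a longer chain there would test with a measured partner.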